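Benzylamine sulfonamides: bromophenyl for dimethoxyphenyl on the propyl chain

The compounds below may be only part of what the source reports. "The series", "measured", "known", "first", "only" and "open" are said of these compounds alone.

Measured so far:
compound 1 `O=S(=O)(NCCCCNCc1ccc(Br)cc1)c1cc(C(F)(F)F)cc(C(F)(F)F)c1` — 2200 nM
compound 2 `COc1ccc(CNCCCNS(=O)(=O)c2cc(C(F)(F)F)cc(C(F)(F)F)c2)cc1OC` — 3600 nM
compound 3 `O=S(=O)(NCCCNCc1ccccc1Cl)c1cc(C(F)(F)F)cc(C(F)(F)F)c1` — 15000 nM

All three share a bis(trifluoromethyl)phenylsulfonamide core joined through a saturated chain to a benzylamine, and all were read in a functional assay on BE(2)-C cells (Homo sapiens) for inhibition, read by MTT assay, with a stated time of 72 h; on this read-out lower numbers stand for stronger inhibition of growth and higher numbers for weaker inhibition of growth. Compound 2 stands second highest of the three numbers; its nearest neighbour is compound 1, which differs from it within the scatter, while compound 3 lies beyond the scatter from it.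

Compound 4 `O=S(=O)(NCCCNCc1ccc(Br)cc1)c1cc(C(F)(F)F)cc(C(F)(F)F)c1` is not yet measured. Against compound 2 the change is 4-bromophenyl in place of 3,4-dimethoxyphenyl on a saturated chain carbon bound to an amine nitrogen.

Within the data shown here, no measured step makes exactly this change. The two steps that touch the same carbon both lead to 2-chlorophenyl: a 6.8-fold higher number from compound 1 to compound 3 (0.83 log units; beyond the scatter) and a 4.2-fold higher number from compound 2 to compound 3 (0.62 log units; beyond the scatter). Both run towards weaker inhibition, but neither involves 4-bromophenyl, so they bound the sensitivity of this position rather than fix the direction here. Compound 1 also carries the 4-bromobenzyl group, on a different chain, and gives 2200 nM; compound 2 gives 3600 nM, and these two sit within the scatter of each other.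

On that basis the expected step in this assay is a 1.2-fold lower number from compound 2 to compound 4 (0.08 log units; within the scatter), essentially none beyond the scatter. Compound 4 is estimated at 3000 nM, with a range from 1200 nM to 8000 nM.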

Compound 4, concentration for 50% growth inhibition: 2700 nM
Compound 4: the middle estimate sits 1.1-fold (0.05 log units) above what was measured; the range from low to high includes it.
By their numbers in this assay, from the lowest: compounds 1, 4 and 2 (each within the scatter of the next); then compound 3.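

In this assay, 3,4-dimethoxyphenyl and 4-bromophenyl on this saturated chain carbon cannot be told apart, with a 1.3-fold lower number from compound 2 to compound 4 (0.12 log units; within the scatter), even though the group that leaves carries 2 hydrogen-bond acceptors and the one that enters carries 0. The position is not indifferent to the aryl group, however: a 5.6-fold lower number from compound 3 to compound 4 (0.74 log units; beyond the scatter) sets 2-chlorophenyl apart from 4-bromophenyl, as it was already set apart from 3,4-dimethoxyphenyl, so among the three groups on this chain only compound 3 departs from the others. The earlier step between compound 1 and compound 3 changed chain and aryl group together, whereas a 1.2-fold higher number from compound 1 to compound 4 (0.09 log units; within the scatter) isolates the chain difference with 4-bromobenzyl held constant and leaves it within the scatter.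

From the compounds shown here alone, whether the gap at compound 3 follows the halogen or its place on the ring remains open, and 4-chlorophenyl and 2-bromophenyl on the same chain would separate the two, while a longer chain carrying 3,4-dimethoxyphenyl would test whether the chain difference stays this small with another aryl group. No measurement offered here accounts for any of these steps.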